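A few compounds are considered here, and "the series" means these few. Any claim that something is new, unique, unknown or untested is made for them only; others in the source may bear on it.

Measured compounds:
compound 1 `COc1ccccc1-n1cc(COc2c(/C=C\C(=O)O)ccc(OC)c2CC=C(C)C)nn1` — "not determined" (no result reported) in a functional assay on T47D cells (Homo sapiens) for cytotoxicity, read by MTT assay, with a stated time of 24 h; a lower number here means a stronger inhibitor, a higher number a weaker inhibitor
compound 2 `COc1ccc(/C=C\C(=O)O)c(OCc2cn(-c3cccc(C#N)c3)nn2)c1CC=C(C)C` — 19200 nM

Going by the values given here, compound 2 is the only compound of the series with a number in this assay; compound 1 carries no result there, so compound 2 stands as the sole reference point and no comparison within the measured set is possible. The step under consideration leads to compound 3 `COc1ccc(/C=C\C(=O)O)c(OCc2cn(-c3ccccc3)nn2)c1CC=C(C)C`. It differs from compound 2 by hydrogen in place of cyano on an aromatic carbon; cut one bond further out, the difference reads 3-cyanophenyl to phenyl. Among the compounds with values here, no step between two measured compounds is available to calibrate this change, so the expected size rests on the single value of compound 2 alone. Compound 3 is expected to lie close to compound 2, with a step of a 1.1-fold higher number from compound 2 to compound 3 (0.06 log units; within the scatter) that does not clearly exceed the usual scatter, so compound 3 is estimated at 22000 nM within 7000 nM to 70000 nM.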

Compound 3, half-maximal inhibitory concentration: 34100 nM
Compound 3: the middle estimate sits 1.6-fold (0.19 log units) below what was measured; the measured number falls inside the stated range.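

In this assay the series now has its first readable step: a 1.8-fold higher number from compound 2 to compound 3 (0.25 log units; within the scatter) for hydrogen in place of cyano on an aromatic carbon, which lies within the usual scatter. At this place on the ring, 3-cyanophenyl and phenyl cannot be told apart by this read-out, so the data do not show that the nitrile is needed for the activity of compound 2. Nothing available bears on the reason for this result.

Going by these compounds, whether an amine or a carboxylic acid at this same place would give a step beyond the scatter remains open. This single step applies only to this pair and says nothing about changes elsewhere on the ring or in the shared core.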